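The source may hold more compounds than are shown below. What is called first, only, known or untested is meant among the compounds shown, and "the series" means these compounds.

In an in vitro assay on P815B cells for inhibition of Indoleamine 2,3-dioxygenase 1 (Mus musculus), tested at 20 uM (on this read-out lower numbers stand for less inhibition and higher numbers for more inhibition at the one concentration tested (going by the name of the read-out)), the compounds share one core, carried by compound 1 `O=C(Cc1cccnc1)c1cc2ccccc2[nH]1`, which gives 13%. Compound 2 `O=C(Cc1cccnc1)c1cc2cc(F)ccc2[nH]1` carries a fluoro on the six-membered carbon ring of the core, and in this assay compound 2 gives 24%; the change is a number 11 percentage points higher from compound 1 to compound 2 (beyond the scatter). Among the measured compounds shown here, compound 3 `O=C(Cc1cccnc1)c1cc2cc(O)ccc2[nH]1` carries a hydroxy at the same position, and in this assay compound 3 is recorded as "not active" (no number reported), so no single number places it against the other two; it stands only as the one compound of the three without a measurable read-out.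

Compound 4 `Cc1ccc2[nH]c(C(=O)Cc3cccnc3)cc2c1` differs from compound 3 by methyl in place of hydroxy on an aromatic carbon. No measured step among these compounds swaps a hydroxy for a methyl, so the size of the move in this assay cannot be taken from a like-for-like pair. What is known is that the unsubstituted compound 1 and the fluoro-bearing compound 2 both give modest readings, while the hydroxy-bearing compound 3 gave none, so a return to a small, uncharged group without donors or acceptors is expected to bring the reading back near those two, with no basis for predicting a step beyond the scatter in either direction. Compound 4 is therefore estimated at 16%, with a range from 0% to 35%.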

Compound 4, a percentage reported as inhibition, at one concentration (the size of the read-out at that concentration, not a potency): 21%
Compound 4: the middle estimate sits 5 percentage points below what was measured, and the stated range covers the measured number.
By their numbers in this assay, from the lowest: compounds 1, 4 and 2 (each within the scatter of the next, the first and the last beyond it).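

With methyl at this position on the six-membered aromatic ring of carbon only, this assay still gives a measurable reading, and methyl cannot be told apart from either comparison group: replacing fluoro with methyl gives a number 3 percentage points lower from compound 2 to compound 4 (within the scatter), while replacing hydrogen with methyl gives a number 8 percentage points higher from compound 1 to compound 4 (within the scatter). Compound 4 therefore shows that this position can carry a small carbon group as well as a fluoro and still give a reading, but the step from compound 3 to compound 4 cannot be read, as compound 3 has no number to set against it. No measurement here explains the difference between the hydroxy of compound 3 and the methyl of compound 4.

The compounds shown leave open whether a methoxy, which keeps the oxygen of the hydroxy while replacing its hydrogen with methyl, would give a reading like that of compound 4 or would be recorded as not active, like compound 3. They also leave open how a chloro, an amine, a carboxylic acid or a longer chain at this position would read in this assay.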